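Trifluoromethyl for fluoro on the anilide ring of compound 1

A few compounds are considered here, and "the series" means these few. Any claim that something is new, unique, unknown or untested is made for them only; others in the source may bear on it.

Compound 1 `COc1ccc(F)cc1NC(=O)CN1CCN(S(=O)(=O)N2CCC(C)CC2)CC1` gives 4900 nM in an assay on HEK293 cells for inhibition of potassium channel subfamily T member 1 (Homo sapiens), read by thallium flux (on this read-out lower numbers stand for stronger inhibition and higher numbers for weaker inhibition), and stands second highest of the three measured numbers. Compound 2 `COc1ccc(Cl)cc1NC(=O)CN1CCN(S(=O)(=O)N2CCC(C)CC2)C[C@@H]1C` gives 3500 nM and compound 3 `CCOc1ccc(Cl)cc1NC(=O)CN1CCN(S(=O)(=O)N2CCC(C)CC2)CC1` gives 7100 nM; both lie within the scatter of compound 1, so no ordering among them can be read. For the measured compounds named here, the only single-place step, a 1.4-fold higher number from compound 1 to compound 3 (0.16 log units; within the scatter), puts chloro for fluoro together with ethoxy for methoxy and stays flat. Compound 4 `COc1ccc(C(F)(F)F)cc1NC(=O)CN1CCN(S(=O)(=O)N2CCC(C)CC2)CC1` carries trifluoromethyl in place of fluoro on an aromatic carbon. Going by the values given here, no measured step varies this position alone, and the one step touching it shows no movement, so for compound 4 the expected step in this assay is a 1.0-fold higher number from compound 1 to compound 4 (0.01 log units; within the scatter), nothing beyond the scatter. The estimate for compound 4 is 5000 nM, with a range from 1500 nM to 16000 nM.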

Compound 4, half-maximal inhibitory concentration: 2400 nM
Estimate against measurement, compound 4: 2.1-fold (0.32 log units) above; measured number inside the range.
By their numbers in this assay, from the lowest: compounds 4, 2, 1 and 3 (each within the scatter of the next, the first and the last beyond it).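

In this assay, trifluoromethyl in place of fluoro, para to a methoxy group, gives a 2.0-fold lower number from compound 1 to compound 4 (0.31 log units; beyond the scatter), a modest step and the first at this position that varies this group alone. The position thus takes trifluoromethyl, with 4 heavy atoms against 1 for fluoro, without loss of inhibition. Nothing measured here bears on the reason for this step. From the compounds shown here alone, whether a nitrile, an amine or a carboxylic acid at this position would extend or reverse the step remains open. Also open, going by these compounds, is whether trifluoromethyl gives the same step with ethoxy in place of methoxy.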